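The compounds below may be only part of what the source reports. "The series", "measured", "known", "first", "only" and "open" are said of these compounds alone.

In a functional assay on HCT-116 cells (Homo sapiens) for cytotoxicity, read by MTT assay, with a stated time of 72 h (a lower number here means a stronger inhibitor, a higher number a weaker inhibitor), compound 1 (`[O-][S+](CCCCN=C=S)Cc1ccccc1`) gives 3660 nM and compound 2 (`O=[N+]([O-])c1ccc(C[S+]([O-])CCCCN=C=S)cc1`) gives 2830 nM. Going by the values given here, these are the only two numbers so far, and they lie within the scatter of each other, so compound 1 has no clear rank. Compound 3 (`[O-][S+](CCCCCCN=C=S)Cc1ccccc1`) departs from compound 1 in the chain: a group of 5 heavy atoms (3 carbon, 1 nitrogen, 1 sulfur; no ring) in place of a group of 3 heavy atoms (1 carbon, 1 nitrogen, 1 sulfur; no ring), on a saturated chain carbon, four bonds along the chain from a sulfur. Among the compounds with values here, the only measured step, a 1.3-fold lower number from compound 1 to compound 2 (0.11 log units; within the scatter), comes from nitro in place of hydrogen on an aromatic carbon, so it does not touch the chain. Within the data shown here, it offers only weak guidance, and no measured step shows what a change on the chain does. No step beyond the scatter is therefore expected in this assay, and no direction can be firmly expected. The estimated change is a 1.3-fold lower number from compound 1 to compound 3 (0.10 log units; within the scatter). For compound 3 the expected value is 2900 nM, with an estimated range of 1200 nM to 7000 nM.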

Compound 3, half-maximal inhibitory concentration: 11600 nM
Estimate against measurement, compound 3: 4.0-fold (0.60 log units) below, outside the stated range (above it).
By their numbers in this assay, from the lowest: compounds 2 and 1 (each within the scatter of the next); then compound 3.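

In this assay, going by these compounds alone, the chain position proves sensitive: the step is a 3.2-fold higher number from compound 1 to compound 3 (0.50 log units; beyond the scatter) and is the first in this set to lie beyond the scatter. It comes with a group of 5 heavy atoms in place of a group of 3 heavy atoms, on a saturated chain carbon, four bonds along the chain from a sulfur, and its direction is toward a weaker inhibitor. No measurement at hand bears on why the number rises.

On these data alone, with a single change at this position, it remains open whether a shorter chain or a still longer chain would continue the same trend. As far as these compounds go, it is also open how this change would read with nitro on the aromatic carbon, or with an amine at the end of the chain.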